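From Cyclohexyl Ring to Open Hexyl Chain

This account rests on a few compounds, and the source may have more. Where it says the series, first, only, none or still open, it means among the compounds named here.

Measured so far in a functional assay on LNCaP cells (Homo sapiens) for cytotoxicity, read by MTT assay, with a stated time of 72 h; a higher number here means a weaker inhibitor, a lower number a stronger inhibitor:
- compound 1 `N[C@H]1CC[C@H](Nc2c(C(=O)NCc3ccc(F)cc3)nc(N3CCCCS3(=O)=O)c3cccnc23)CC1`: 8000 nM
- compound 2 `N[C@H]1CC[C@H](Nc2c(C(=O)NCc3ccc(F)cc3)nc(Br)c3cccnc23)CC1`: 5000 nM
- compound 3 `N[C@H]1CC[C@H](Nc2c(C(=O)NCc3ccc(F)cc3)nc(N3CCCCC3)c3cccnc23)CC1`: "not determined" (no result reported)

Going by the values given here, only two numbers exist so far. Compound 2, at 5000 nM, lies within the scatter of compound 1, so neither can be ranked above the other. Compound 3 adds no number to the comparison.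

Compound 4 `NCCCCCCNc1c(C(=O)NCc2ccc(F)cc2)nc(Br)c2cccnc12` keeps the bromine of compound 2 but alters a different group: 6-aminohexyl in place of 4-aminocyclohexyl on a nitrogen on an aromatic ring. In words, 6-aminohexyl stands in place of 4-aminocyclohexyl on a nitrogen on an aromatic ring, so the group that enters has no ring.

Among the compounds with values here, no measured step changes this group. Within the data shown here, the only step available is a 1.6-fold lower number from compound 1 to compound 2 (0.20 log units; within the scatter), which concerns a group on an aromatic carbon and therefore offers weak guidance at best. With no evidence favouring either direction, no shift beyond the scatter is expected in this assay. The expected step is a 1.3-fold lower number from compound 2 to compound 4 (0.10 log units; within the scatter). This estimate rests on very little, so its range is wide. For compound 4 the estimated value is 4000 nM, with an expected range from 1000 nM to 12000 nM.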

Compound 4, half-maximal inhibitory concentration: 8000 nM
The estimate for compound 4 lay 2.0-fold (0.30 log units) below the measured number; low and high end bracket the measured number.
By their numbers in this assay, from the lowest: compounds 2, 1 and 4 (each within the scatter of the next).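

Going by these compounds alone, compound 4 gives the first reading of a change to the group on the nitrogen on the aromatic ring, and in this assay the result is a 1.6-fold higher number from compound 2 to compound 4 (0.20 log units; within the scatter). The 4-aminocyclohexyl and 6-aminohexyl groups have the same heavy-atom count, but the first has a ring and defined stereocentres while the second has neither, so this pair isolates those features, and with bromine on the core, the two compounds cannot be told apart in this measurement. Nothing measured here offers an explanation for this result.

This is a single pair, so it cannot show whether an open chain and a cyclohexyl ring would also stand level with another group in place of the bromine. It also leaves open what a shorter chain such as 4-aminobutyl, a longer chain such as 8-aminooctyl, or a carboxylic acid in place of the amine would do at this position, including whether any of them would give a step beyond the scatter.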